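Removing the amide methyl from compound 3

This account rests on a few compounds, and the source may have more. Where it says the series, first, only, none or still open, it means among the compounds named here.

Of the compounds shown here, three have been measured in an assay on IM-9 cells for binding affinity to Substance-P receptor (Homo sapiens); on this read-out lower numbers stand for stronger inhibition and higher numbers for weaker inhibition. Compound 1 `Cc1ccc(-c2c(C(=O)N(C)Cc3cc(Cl)cc(Cl)c3)n(C)c(=O)c3ncccc23)cc1` gives 3.4 nM in this assay, and compound 2 `Cc1ccccc1-c1c(C(=O)N(C)Cc2ccccc2Cl)n(C)c(=O)c2ccccc12` gives 19 nM. Compound 3 `CN(Cc1cc(C(F)(F)F)cc(C(F)(F)F)c1)C(=O)c1c(-c2ccc(F)cc2)c2cccnc2c(=O)n1C` gives 0.21 nM, the lowest of the three numbers; its gap to compound 1 and its wider gap to compound 2 both lie beyond the scatter, so compound 3 stands as the strongest binder of the three.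

Compound 4 `Cn1c(C(=O)NCc2cc(C(F)(F)F)cc(C(F)(F)F)c2)c(-c2ccc(F)cc2)c2cccnc2c1=O` has not yet been measured. It differs from compound 3 in a single place: hydrogen in place of methyl on an amide-type nitrogen. Everything else in the two structures is the same.

For the measured compounds named here, no measured pair in this set shows what this particular change does, so the expectation rests only on compound 3 and on the change itself. Because compound 3 already gives 0.21 nM, there is far more room for the number to rise than to fall, and a loss of affinity beyond the scatter is expected rather than no change. Compound 4 is therefore expected to give 3 nM, with a range from 0.5 nM to 20 nM. This estimate amounts to an expected step from compound 3 to compound 4 of a 14-fold higher number from compound 3 to compound 4 (1.15 log units; beyond the scatter).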

Compound 4, half-maximal inhibitory concentration: 1.1 nM
The estimate for compound 4 lay 2.7-fold (0.44 log units) above the measured number; measured number inside the range.
By their numbers in this assay, from the lowest: compound 3; then compound 4; then compound 1; then compound 2.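

In this assay, for the compounds shown here, hydrogen in place of methyl on the amide-type nitrogen gives a 5.2-fold higher number from compound 3 to compound 4 (0.72 log units; beyond the scatter) and, being a modest step beyond the scatter, provides the first direct reading of this change, which no earlier pair could supply. The methyl at this position therefore counts in the measured affinity, yet compound 4, with the amide hydrogen, still gives 1.1 nM, so a low number in this pair does not depend on the methyl being present. Nothing measured here bears on why the number rises with this change.

As far as these compounds go, this reading rests on one pair, so it remains open whether the same change would produce a step of similar size in compound 1 or compound 2, which also carry a methyl on this nitrogen and differ from compound 3 elsewhere. The compounds shown also leave open how an ethyl group, a longer chain or a cyclopropyl group on this nitrogen would compare with the methyl and the hydrogen.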